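A cyclopropylmethyl extension of the methoxy head group

The compounds below may be only part of what the source reports. "The series", "measured", "known", "first", "only" and "open" are said of these compounds alone.

Measured so far:
compound 1 `COc1cc(C)c(-c2cccc(COc3ccc(S(=O)(=O)CC(=O)O)cc3)c2)c(C)c1`: 57.5 nM
compound 2 `COc1cc(C)c(-c2cccc(COc3ccc4c(c3)C(=O)CC4CC(=O)O)c2)c(C)c1`: 234 nM
compound 3 `COc1cc(C)c(-c2cccc(COc3ccc4c(c3)C(O)CC4CC(=O)O)c2)c(C)c1`: 550 nM

In a functional assay on CHO cells for agonist activity at Free fatty acid receptor 1 (Homo sapiens), read by FLIPR and calcium flux (on this read-out higher numbers stand for an effect only at larger amounts of compound and lower numbers for an effect already at smaller amounts), compound 1 stands lowest of the three numbers; compound 2 and compound 3 both lie above it by more than the scatter, with compound 3 the furthest away. Compound 4 `Cc1cc(OCC2CC2)cc(C)c1-c1cccc(COc2ccc(S(=O)(=O)CC(=O)O)cc2)c1` shares the shared core of compound 1 and differs from it only by cyclopropyl in place of hydrogen on a saturated chain carbon bound to an oxygen on an aromatic ring. Going by the values given here, no step of this kind has been measured among the three compounds. For the step from compound 1 to compound 4 in this assay, a small change is expected, leaning slightly downward and most likely not beyond the scatter, at a 1.4-fold lower number from compound 1 to compound 4 (0.16 log units; within the scatter). Compound 4 is therefore estimated at 40 nM, within a range from 12 nM to 150 nM.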

Compound 4, half-maximal effective concentration: 79.4 nM
For compound 4 the middle estimate is 2.0-fold (0.30 log units) below the measured one; the range from low to high includes it.
By their numbers in this assay, from the lowest: compounds 1 and 4 (each within the scatter of the next); then compound 2; then compound 3.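

Going by these compounds alone, the extension of methoxy to cyclopropylmethoxy gives the first step that can be read at this position in this assay, and it stays within the scatter, with a 1.4-fold higher number from compound 1 to compound 4 (0.14 log units; within the scatter). On the shared core of compound 1, this place therefore accepts a cyclopropyl group in place of hydrogen without a change beyond the scatter. Nothing at hand gives a reason for this result.

From the compounds shown here alone, it remains open whether a longer chain, a cyclobutyl group or an amine at this place would also stay within the scatter. Also open, going by these compounds, is whether cyclopropylmethoxy would do the same on the cores of compound 2 and compound 3.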